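The compounds below may be only part of what the source reports. "The series", "measured", "known", "first", "only" and "open" are said of these compounds alone.

Measured compounds in the series:

Compound 1 `CCN(CC)c1ccc2cc(C(=O)c3ccc(N4CCN(C(=O)CN5CCNCC5)CC4)cc3)oc2c1` — 1870 nM
Compound 2 `CCN(CC)c1ccc2cc(C(=O)c3ccc(N4CCN(C(=O)CN5CCN(C(=O)/C=C/c6ccccc6)CC5)CC4)cc3)oc2c1` — 6810 nM
Compound 3 `CCN(CC)c1ccc2cc(C(=O)c3ccc(N4CCN(C(=O)CN5CCN(Cc6ccc(F)c(F)c6)CC5)CC4)cc3)oc2c1` — 26300 nM

All three were read in a functional assay on HCT-116 cells (Homo sapiens) for cytotoxicity, read by MTT assay, with a stated time of 48 h; a lower number here means a stronger inhibitor, a higher number a weaker inhibitor. Compound 1 gives the lowest number of the three: compound 2 lies nearer to it and compound 3 furthest. Both measured steps put a group on the ring amine nitrogen that is unsubstituted in compound 1, and both raise the number: a 3.6-fold higher number from compound 1 to compound 2 (0.56 log units; beyond the scatter), and a 14-fold higher number from compound 1 to compound 3 (1.15 log units; beyond the scatter). Comparing the two substituted compounds, a 3.9-fold higher number from compound 2 to compound 3 (0.59 log units; beyond the scatter).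

Compound 4 `CCN(CC)c1ccc2cc(C(=O)c3ccc(N4CCN(C(=O)CN5CCN(Cc6ccc(C#N)cc6)CC5)CC4)cc3)oc2c1` is not yet measured. It differs from compound 1 as follows: 4-cyanobenzyl in place of hydrogen on an amine nitrogen in a ring. Within the data shown here, of the two measured steps, the one to compound 3 is the closer parallel, since it also places a substituted benzyl on the same ring nitrogen; that step was large. The step to compound 2 is the weaker guide and was modest. Among the measured compounds shown here, the step from compound 1 to compound 4 is therefore expected to raise the number in this assay beyond the scatter, by roughly an 8.0-fold higher number from compound 1 to compound 4 (0.90 log units; beyond the scatter), with the range held wide because only one benzyl example is available. For compound 4 the estimate in this assay is 15000 nM, between 5000 nM and 40000 nM.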

Compound 4, half-maximal inhibitory concentration: > 40000 nM
Compound 4: only a limit was reported (the forecaster's own chance of this, stated with the estimate: 5%); at least 2.6-fold (0.42 log units) between middle value and limit.
By their numbers in this assay, from the lowest: compound 1; then compound 2; then compound 3. At a limit, above all of these: compound 4.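

Compound 4 is reported in this assay only as a limit, not as a number: the limit of > 40000 nM in this assay, at which 1 of the 4 values shown sits. On this amine nitrogen in a ring, a second substituted benzyl group again moves away from the free nitrogen of compound 1, with an at least 21-fold higher number from compound 1 to compound 4 (1.33 log units; beyond the scatter), and the 4-cyanobenzyl group also stands apart from the (2-phenylethenyl)carbonyl group, with an at least 5.8-fold higher number from compound 2 to compound 4 (0.76 log units; beyond the scatter). Compound 1 therefore keeps the lowest number of the four, but the two substituted benzyl compounds cannot be ordered with confidence, as the comparison gives only a floor: an at least 1.5-fold higher number from compound 3 to compound 4 (0.18 log units; that floor lies within the scatter).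

The compounds shown leave open whether any substituent on this nitrogen can keep the number close to that of compound 1, for example a small alkyl group such as methyl, or an acetyl group. They also leave open whether the rise belongs to the benzyl group itself or to the groups on its ring, a question that an unsubstituted benzyl or a 4-methoxybenzyl group on the same nitrogen would address.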